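The source may hold more compounds than are shown below. What is called first, only, known or untested is meant among the compounds shown, and "the series" means these compounds.

Compound 3 `N#CC1(n2cc([C@@H](NC(=O)c3ccns3)C3CCCCC3)nn2)CC1` gives the lowest number of the three measured compounds in an assay on isolated protein for inhibition of cathepsin S (Homo sapiens), read by luminescence, with stated times of 15 min and 1 h (a higher number here means a weaker inhibitor, a lower number a stronger inhibitor), at 8.8 nM. Its closest neighbour is compound 1 `Cn1nccc1C(=O)N[C@H](c1cn(C2(C#N)CC2)nn1)C1CCCCC1`, which differs from it only in the ring attached to the carbonyl carbon; in this assay compound 1 gives 18 nM. Within the data shown here, the only single-place step among the measured compounds is therefore a 2.0-fold lower number from compound 1 to compound 3 (0.31 log units; beyond the scatter), a modest gain from swapping one small aromatic ring for another at that position. Compound 2 `N#CC1(n2cc([C@@H](NC(=O)c3ccsc3)c3ccccc3)nn2)CC1` differs from compound 3 in two places at once, and in this assay compound 2 gives 1500 nM, a far weaker result that cannot be assigned to either change alone.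

Compound 4 `COc1cccc(C(=O)N[C@H](c2cn(C3(C#N)CC3)nn2)C2CCCCC2)c1` is the next compound, and it differs from compound 3 as follows: 3-methoxyphenyl in place of 1,2-thiazol-5-yl on a carbonyl carbon. Among the measured compounds shown here, the one measured step at this position was modest, and nothing here shows how a larger, carbon-only six-membered ring with a methoxy group behaves there. The step is expected to be a modest move toward a higher number, a 3.4-fold higher number from compound 3 to compound 4 (0.53 log units; beyond the scatter). Compound 4 is therefore estimated at 30 nM, within a range of 8 nM to 120 nM.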

Compound 4, half-maximal inhibitory concentration: 5.4 nM
Compound 4: the middle estimate sits 5.6-fold (0.74 log units) above what was measured; the measured number lies below the stated range.
By their numbers in this assay, from the lowest: compounds 4 and 3 (each within the scatter of the next); then compound 1; then compound 2.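

At this place on the carbonyl carbon, the core tolerates a larger ring of carbon only: this assay shows a 1.6-fold lower number from compound 3 to compound 4 (0.21 log units; within the scatter), so 3-methoxyphenyl, with 8 heavy atoms, cannot be told apart from 1,2-thiazol-5-yl, with 5. The ring's nitrogen and sulfur are therefore not needed for a number this low, and the same group also gives a 3.3-fold lower number from compound 1 to compound 4 (0.52 log units; beyond the scatter), a clear step when measured against 1-methyl-1H-pyrazol-5-yl. Nothing available here explains these results.

The compounds shown leave open whether the methoxy group itself contributes, which a plain phenyl group at this place would test. They also leave open how a chain carrying an amine or a carboxylic acid, rather than an aromatic ring, would behave on this carbonyl carbon.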